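The source may report more compounds than this note shows. Statements on the series, on what has been measured and on what is new or still open speak of the compounds shown alone.

- Compound 1 `NC(=O)c1cc(Cl)ccc1NC(=O)COc1ccccc1`: 1430 nM
- Compound 2 `NC(=O)c1cc(I)ccc1NC(=O)COc1ccccc1`: 344 nM
- Compound 3 `COc1ccc(NC(=O)COc2ccccc2)c(C(N)=O)c1`: not yet measured

In a functional assay on NCI/ADR-RES cells (Homo sapiens) for inhibition (a higher number here means a weaker inhibitor of growth, a lower number a stronger inhibitor of growth), compound 2 holds the lower of the two numbers at 344 nM, while compound 1 stands at 1430 nM. The change now in view is methoxy in place of iodo on an aromatic carbon, meta to a carbamoyl group and para to a large group. Within the data shown here, one measured step bears on this place: a 4.2-fold lower number from compound 1 to compound 2 (0.62 log units; beyond the scatter), which swaps chloro for iodo. Among the measured compounds shown here, it shows that the number in this assay moves with the group at this place, but no measured compound carries methoxy, so the guide is indirect. Compound 3 gives up the iodo of compound 2, the group that came with the lower number in that step, so a modest move to a higher number is expected, of about the same size and with a wide margin. The estimated change is a 3.8-fold higher number from compound 2 to compound 3 (0.58 log units; beyond the scatter). For compound 3 the expected value is 1300 nM, with an estimated range of 350 nM to 5000 nM.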

Compound 3, concentration for 50% growth inhibition: 418 nM
Compound 3: the middle estimate sits 3.1-fold (0.49 log units) above what was measured; measured number inside the range.
By their numbers in this assay, from the lowest: compounds 2 and 3 (each within the scatter of the next); then compound 1.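

In this assay, methoxy at this place, meta to a carbamoyl group and para to a large group, reads the same as iodo within the scatter, with a 1.2-fold higher number from compound 2 to compound 3 (0.08 log units; within the scatter) (a gap too small to rank the two groups). Chloro now stands apart from two different groups rather than one, with a 3.4-fold lower number from compound 1 to compound 3 (0.53 log units; beyond the scatter) matching in direction the earlier step to iodo, so a number near that of compound 2 is not tied to iodo alone, even though methoxy and iodo differ in their heavy atoms and in their count of hydrogen-bond acceptors. Nothing measured on these compounds accounts for why the two groups read alike or why chloro differs from them.

The compounds shown leave open how an amine, a carboxylic acid or a longer chain such as ethoxy would read at this place, and whether plain hydrogen would fall with chloro or with iodo and methoxy. They also leave open whether the match between methoxy and iodo would survive a change elsewhere on the shared core.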